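Aryl amide swaps on a shared core leave potency unchanged

The compounds below may be only part of what the source reports. "The series", "measured", "known", "first", "only" and "open" are said of these compounds alone.

Compound 3 `Cc1ccccc1C(=O)Nc1cccc(/C=C/C(=O)c2nc3ccccc3[nH]2)c1` gives 1870 nM in a functional assay on HCT-116 cells (Homo sapiens) for antiproliferative activity, read by MTT assay, with a stated time of 48 h (a lower number here means a stronger inhibitor, a higher number a weaker inhibitor), the lowest of the three numbers measured, though compound 1 `O=C(Nc1cccc(/C=C/C(=O)c2nc3ccccc3[nH]2)c1)c1ccccc1` at 2440 nM and compound 2 `O=C(Nc1cccc(/C=C/C(=O)c2nc3ccccc3[nH]2)c1)c1ccc(Cl)cc1` at 2270 nM both sit within the scatter of it. Compound 4 `COc1ccc(C(=O)Nc2cccc(/C=C/C(=O)c3nc4ccccc4[nH]3)c2)cc1` differs from compound 3 only in the aryl group on the amide: 4-methoxyphenyl in place of 2-methylphenyl on a carbonyl carbon. Earlier changes at this same group were small: a 1.1-fold lower number from compound 1 to compound 2 (0.03 log units; within the scatter), a 1.3-fold lower number from compound 1 to compound 3 (0.12 log units; within the scatter), and a 1.2-fold lower number from compound 2 to compound 3 (0.08 log units; within the scatter). Since none of these moved beyond the scatter, no step beyond the scatter is expected here either, which means a 1.1-fold higher number from compound 3 to compound 4 (0.05 log units; within the scatter) for compound 4. Compound 4 is therefore estimated at 2100 nM in this assay, with a likely range from 1000 nM to 4500 nM.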

Compound 4, half-maximal inhibitory concentration: 4880 nM
Estimate against measurement, compound 4: 2.3-fold (0.37 log units) below, outside the stated range (above it).
By their numbers in this assay, from the lowest: compounds 3, 2, 1 and 4 (each within the scatter of the next, the first and the last beyond it).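

In this assay this aryl group on the amide carbonyl can, unlike in the earlier swaps, move the number beyond the scatter: 4-methoxyphenyl in place of 2-methylphenyl gives a 2.6-fold higher number from compound 3 to compound 4 (0.42 log units; beyond the scatter) and methoxy in place of chloro gives a 2.1-fold higher number from compound 2 to compound 4 (0.33 log units; beyond the scatter) as a second modest step. Methoxy in place of hydrogen, with a 2.0-fold higher number from compound 1 to compound 4 (0.30 log units; within the scatter) as its step, stays within the scatter, so the shift shows only against some partners. From the compounds shown here alone, whether an amine or a carboxylic acid on this ring would move the number further stays open. Nothing shown here explains why the methoxy compound reads as it does.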